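The source may report more compounds than this note shows. Statements on the series, on what has been measured and on what is new or still open speak of the compounds shown alone.

Measured so far in a functional assay on MCF7 cells (Homo sapiens) for cytotoxicity, read by MTT assay, with a stated time of 72 h; on this read-out higher numbers stand for weaker inhibition and lower numbers for stronger inhibition:
Compound 1 `CCCCCCCCCCCCNc1nc(SCc2ccc(C(F)(F)F)cc2)nc2ccccc12`: > 50000 nM, a limit of the assay.
Compound 2 `FC(F)(F)c1ccc(CSc2nc(Nc3ccccc3C(F)(F)F)c3ccccc3n2)cc1`: > 50000 nM, a limit of the assay.
Compound 3 `CCOc1ccccc1Nc1nc(SCc2ccc(C(F)(F)F)cc2)nc2ccccc12`: > 50000 nM, a limit of the assay.

Compound 3 stands at the same limit as the other two entries, so no order can be set among compounds 1, 2 and 3 in this assay; none of the three values is a number. The step that the two limits leave unreadable from compound 2 to compound 3 cannot be read, both of its ends being limits, which follows from the limit of > 50000 nM in this assay, at which 3 of the 3 values shown sit.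

Compound 4 `Cc1ccc(Nc2nc(SCc3ccc(C(F)(F)F)cc3)nc3ccccc23)cc1` differs from compound 3 in one place: 4-methylphenyl in place of 2-ethoxyphenyl on a nitrogen on an aromatic ring. For the measured compounds named here, no measured step bears on this exchange. Going by the values given here, the one step at the same nitrogen, a step that the two limits leave unreadable from compound 2 to compound 3, is unreadable, and compounds 1 and 2, which also differ at that nitrogen, both sit at a limit. There is therefore no measured basis for a step beyond the scatter in either direction, and the expectation is that compound 4 also remains at a limit. Compound 4 is expected to give 70000 nM, within 20000 nM to 250000 nM, in this assay. The step that the limit leaves unreadable from compound 3 to compound 4 that this estimate implies is expected to be essentially none.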

Compound 4, half-maximal inhibitory concentration: > 50000 nM
Compound 4 ended at the assay's limit; the forecaster's own chance of this, stated with the estimate: 80%; the middle value does not contradict the limit.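

In this assay compound 4 gives > 50000 nM, a limit of the assay. The steps to compound 4 from compound 2 and compound 3 cannot be read, as both ends of each are limits: the limit of > 50000 nM in this assay, at which 4 of the 4 values shown sit.

From the compounds shown here alone, whether any group on that nitrogen brings the shared core to a measurable value remains open.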